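Swapping ethoxycarbonyl for 2-chloroethenyl

A few compounds are considered here, and "the series" means these few. Any claim that something is new, unique, unknown or untested is made for them only; others in the source may bear on it.

Of the compounds shown here, three with a shared core have been measured in a physicochemical assay for lipophilicity, measured as octanol-water partition; on this read-out lower numbers stand for lower lipophilicity and higher numbers for higher lipophilicity. Compound 1 `C#CCc1c(Cl)cc(N/C=N/OCSC)cc1Cl` gives 3.6, compound 2 `C#CCc1c(Cl)cc(N/C=N/OCOCC)cc1Cl` gives 3.5, and compound 3 `C#CCc1c(Cl)cc(N/C=N/OCC(=O)OCC)cc1Cl` gives 3.6. Compound 3 therefore stands level with compound 1, and all three numbers lie within the scatter of one another.

Compound 4 `C#CCc1c(Cl)cc(N/C=N/OC/C=C/Cl)cc1Cl` keeps the shared core but puts 2-chloroethenyl in place of ethoxycarbonyl on a saturated chain carbon bound to an oxygen.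

Among the measured compounds shown here, the measured steps at this same place are the only guide, and all of them are small. Two involve the ethoxycarbonyl group that now leaves: no change at the digits printed from compound 1 to compound 3 (within the scatter) and a number 0.10 log units higher from compound 2 to compound 3 (within the scatter). The third is a number 0.10 log units lower from compound 1 to compound 2 (within the scatter). None of these steps brings in a chlorine-bearing group, so they do not test this change directly. The hydrogen-bond acceptors counted on the leaving group also do not return in the entering one. A modest rise in this assay therefore seems more likely than a fall, and the expected step is a number 0.30 log units higher from compound 3 to compound 4 (within the scatter). For compound 4 the estimated value is 3.9, with an expected range from 3.4 to 4.4.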

Compound 4, partition coefficient: 3.9
Beside the measured number, compound 4's estimate shows no gap at the digits printed, and the stated range covers the measured number.
By their numbers in this assay, from the lowest: compounds 2, 1, 3 and 4 (each within the scatter of the next, the first and the last beyond it).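

The groups first seen on this saturated chain carbon bound to an oxygen, methylsulfanyl, ethoxy and ethoxycarbonyl, all gave numbers within the scatter of one another in this assay, so this position had not yet produced a step that could be told apart from repeat-measurement noise. Among the compounds shown here, with 2-chloroethenyl in place of ethoxy, the reading is a number 0.40 log units higher from compound 2 to compound 4 (beyond the scatter), the first step at this position to pass the scatter, though only modestly. The other two comparisons fall short of that: with 2-chloroethenyl in place of ethoxycarbonyl the reading is a number 0.30 log units higher from compound 3 to compound 4 (within the scatter), and with 2-chloroethenyl in place of methylsulfanyl it is a number 0.30 log units higher from compound 1 to compound 4 (within the scatter), so the new group stands clearly apart from ethoxy alone.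

No measurement shown here gives a reason for these steps. As far as these compounds go, it remains open whether the chlorine itself matters, which a plain ethenyl group would help to test, and how an amine, a carboxylic acid or a longer alkyl chain at this position would read in this assay.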